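The source may hold more compounds than are shown below. What is called first, only, known or untested is meant among the compounds shown, and "the series" means these compounds.

Three amide-bearing analogues on the shared core have so far been examined in a functional assay on A549 cells (Homo sapiens) for antiproliferative activity, read by MTT assay, with a stated time of 72 h; on this read-out lower numbers stand for stronger inhibition and higher numbers for weaker inhibition. Compound 1 `CNC(=O)c1cc(Oc2ccc(NC(=O)c3cc4cccnc4n(-c4ccc(F)cc4)c3=O)cc2)ccn1` gives 110 nM in this assay, compound 2 `CCNC(=O)c1cc(Oc2ccc(NC(=O)c3cc4cccnc4n(-c4ccc(F)cc4)c3=O)cc2)ccn1` gives 120 nM, and compound 3 `CCCNC(=O)c1cc(Oc2ccc(NC(=O)c3cc4cccnc4n(-c4ccccc4)c3=O)cc2)ccn1` gives 95 nM. Compound 3 therefore holds the lowest of the three numbers, but its gap to compound 1 and to compound 2 lies within the scatter of this assay, so no ordering among the three can be claimed.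

Compound 4 `CCCNC(=O)c1cc(Oc2ccc(NC(=O)c3cc4cccnc4n(-c4ccc(F)cc4)c3=O)cc2)ccn1` is the next analogue. It differs from compound 3 in one place: fluoro in place of hydrogen on an aromatic carbon. Among the compounds with values here, the only single-point step measured so far, a 1.1-fold higher number from compound 1 to compound 2 (0.04 log units; within the scatter), concerns the chain on the amide nitrogen rather than the aromatic ring and so does not bear directly on this change. Compound 2 and compound 3, which differ both in that chain and in the fluoro substituent, give values in this assay that lie within the scatter of each other. Within the data shown here, no step in the data points to a shift beyond the scatter from the fluoro substituent alone. Compound 4 is therefore expected to give 100 nM in this assay, with a range from 50 nM to 200 nM, which would mean a step of a 1.1-fold higher number from compound 3 to compound 4 (0.02 log units; within the scatter).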

Compound 4, half-maximal inhibitory concentration: 62 nM
Compound 4: middle estimate off by 1.6-fold (0.21 log units), on the high side, and the stated range covers the measured number.
By their numbers in this assay, from the lowest: compounds 4, 3, 1 and 2 (each within the scatter of the next).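

Within the data shown here, with this result the change from phenyl to 4-fluorophenyl, on an aromatic carbon para to a large group, can be read on its own for the first time: in this assay it gives a 1.5-fold lower number from compound 3 to compound 4 (0.19 log units; within the scatter) and so does not leave the scatter. With the 4-fluorophenyl group held fixed, the methyl, ethyl and propyl amides can now all be set against one another, and a 1.8-fold lower number from compound 1 to compound 4 (0.25 log units; within the scatter) and a 1.9-fold lower number from compound 2 to compound 4 (0.29 log units; within the scatter) join a 1.1-fold higher number from compound 1 to compound 2 (0.04 log units; within the scatter) as steps that all stay within the scatter, so neither the fluoro group nor the length of these short chains separates the compounds on this read-out. No measurement at hand speaks to why the numbers stand as they do.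

The compounds shown leave open whether a chloro or methoxy group in place of the fluoro at this position would give a step beyond the scatter. They also leave open whether a longer chain such as butyl, or a chain ending in an amine or a carboxylic acid, on the amide nitrogen would do so.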